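Swapping Trifluoromethyl for Chloro on a Seizure Model Series

A few compounds are considered here, and "the series" means these few. Any claim that something is new, unique, unknown or untested is made for them only; others in the source may bear on it.

Three compounds share one core, an imide ring carrying a methyl and a phenyl group, joined through a short linker to an amide. In compound 1 `CC1(c2ccccc2)CC(=O)N(CC(=O)N2CCOCC2)C1=O` that amide sits on a morpholine ring, and in a functional assay on the whole organism (strain CD-1) with Mus musculus as the target, in the maximal electroshock model, with a stated time of 2 h (a higher number here means that more compound is needed for the effect, a lower number that less compound is needed), compound 1 gives 300 mg/kg. Compound 2 `CC1(c2ccccc2)CC(=O)N(CC(=O)N2CCN(c3ccccc3Cl)CC2)C1=O` carries instead a piperazine bearing a chlorophenyl group, and in this assay compound 2 is reported as "not active" (no number reported). Compound 3 `CC1(c2ccccc2)CC(=O)N(CC(=O)N2CCN(c3cccc(C(F)(F)F)c3)CC2)C1=O` has the piperazine with a 3-(trifluoromethyl)phenyl group, and in this assay compound 3 gives 300 mg/kg, level with compound 1 at the digits reported, within the scatter.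

Compound 4 `CC1(c2ccccc2)CC(=O)N(CC(=O)N2CCN(c3cccc(Cl)c3)CC2)C1=O` differs from compound 3 in one place: chloro in place of trifluoromethyl on an aromatic carbon. Within the data shown here, no measured pair shows this exact change here, so its size can only be guessed. With compound 1 and compound 3 sitting at the same value, the expected step from compound 3 to compound 4 is small, no change at the digits printed from compound 3 to compound 4 (within the scatter), none beyond the scatter. Compound 4 is therefore estimated at 300 mg/kg, between 100 mg/kg and 600 mg/kg, though compound 2 shows that a chlorophenyl variant can also fall to inactivity.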

Compound 4, minimum effective dose: 300 mg/kg
For compound 4 middle estimate and measured number coincide at the digits printed; low and high end bracket the measured number.
By their numbers in this assay, from the lowest: compounds 1, 3 and 4 (each within the scatter of the next).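

In this assay, among these compounds, exchanging trifluoromethyl for chloro on this aromatic carbon gives no change at the digits printed from compound 3 to compound 4 (within the scatter), so this pair offers the first direct reading of the change, and the two groups cannot be told apart at this position. Compound 2 carries its chloro at a different place on the phenyl ring and is reported as "not active" (no number reported), so a chlorophenyl group does not by itself mean a compound without a number, and the place of the chloro may matter. No measurement shown here offers an explanation for either result.

The compounds shown leave open whether a different group at this position, such as a methoxy group, an amine or a carboxylic acid, would move the dose needed. They also leave open what a longer chain between the imide ring and the amide would do.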